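A few compounds are considered here, and "the series" means these few. Any claim that something is new, unique, unknown or untested is made for them only; others in the source may bear on it.

In a functional assay on PC-3 cells (Homo sapiens) for cytotoxicity, read by MTT assay, with a stated time of 72 h (on this read-out higher numbers stand for weaker inhibition and lower numbers for stronger inhibition), compound 1 `N#Cc1ccc(/C=C/C(=O)Nc2cc3c(Nc4ccc(F)c(Cl)c4)ncnc3cc2O[C@H]2CCOC2)cc1` gives 36600 nM and compound 2 `COc1cc(/C=C/C(=O)Nc2cc3c(Nc4ccc(F)c(Cl)c4)ncnc3cc2O[C@H]2CCOC2)cc(OC)c1O` gives 26500 nM. These two values lie within the scatter of each other, so compound 2 stands level with compound 1 on the numbers available. Compound 3 `O=C(/C=C/c1ccc(F)cc1Cl)Nc1cc2c(Nc3ccc(F)c(Cl)c3)ncnc2cc1O[C@H]1CCOC1` keeps the shared core and carries 2-chloro-4-fluorophenyl in place of 4-hydroxy-3,5-dimethoxyphenyl on a double-bonded chain carbon bound to a double-bonded chain carbon. For the measured compounds named here, only one measured step bears on this change, the exchange at the same place that links compound 2 to compound 1, and it was small: a 1.4-fold lower number from compound 1 to compound 2 (0.14 log units; within the scatter). Going by the values given here, that is a single step, and no measured compound carries the entering group. Even so, no step beyond the scatter is expected in this assay. The estimated step is a 1.1-fold lower number from compound 2 to compound 3 (0.03 log units; within the scatter). Compound 3 is expected at 25000 nM, within an estimated range of 10000 nM to 55000 nM.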

Compound 3, half-maximal inhibitory concentration: 7150 nM
Compound 3: middle estimate off by 3.5-fold (0.54 log units), on the high side; measured number outside the range, below it.
By their numbers in this assay, from the lowest: compound 3; then compounds 2 and 1 (each within the scatter of the next).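

In this assay the group on a double-bonded chain carbon bound to a double-bonded chain carbon does matter: 2-chloro-4-fluorophenyl brings a 3.7-fold lower number from compound 2 to compound 3 (0.57 log units; beyond the scatter) and also a 5.1-fold lower number from compound 1 to compound 3 (0.71 log units; beyond the scatter) at the same place. Both steps are modest, yet they pass the scatter, which the exchange between 4-cyanophenyl and 4-hydroxy-3,5-dimethoxyphenyl did not do, so this position is not indifferent to what it carries. No measured finding is at hand to explain why the 2-chloro-4-fluorophenyl group stands apart from the other two.

As far as these compounds go, what a phenyl ring carrying only the chlorine or only the fluorine would give remains open. So does the outcome of an amine such as dimethylamino on that ring, or of a saturated ring such as morpholine in place of the phenyl.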